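The compounds below may be only part of what the source reports. "The series", "measured", "known", "first", "only" and "open" are said of these compounds alone.

Working notes on the series. Compound 1 `O=C(NCc1cn[nH]c1)Nc1ccc(S(=O)(=O)c2ccccc2)cc1` gives 28 nM in an assay on isolated protein for activation of Nicotinamide phosphoribosyltransferase (Homo sapiens); on this read-out higher numbers stand for an effect only at larger amounts of compound and lower numbers for an effect already at smaller amounts. Compound 2 `O=C(NCc1ccncc1)Nc1ccc(S(=O)(=O)c2ccc(Cl)cc2)cc1` gives 126 nM in this assay, and compound 3 `CN(C1CCCC1)S(=O)(=O)c1ccc(NC(=O)NCc2ccncc2)cc1` gives 123 nM. On these numbers compound 3 stands second highest of the three; the nearest value is that of compound 2, which differs from it within the scatter, and the furthest is that of compound 1, which is lower beyond the scatter.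

Compound 4 `O=C(NCc1ccncc1)Nc1ccc(S(=O)(=O)c2ccccc2)cc1` is not yet measured. The change from compound 3 to compound 4 is phenyl in place of cyclopentyl(methyl)amino on a sulfonyl sulfur. Among the compounds with values here, the only measured step that bears on this position is a 1.0-fold lower number from compound 2 to compound 3 (0.01 log units; within the scatter), which exchanged one substituent on the sulfonyl sulfur for another without leaving the scatter. Within the data shown here, no measured step separates a phenyl from a cyclopentyl(methyl)amino group at this position, and compound 1, which does carry a phenyl on the sulfonyl sulfur, differs from compound 4 also elsewhere, so it gives no direct step. The step from compound 3 to compound 4 in this assay is therefore expected to stay within the scatter, as a 1.2-fold lower number from compound 3 to compound 4 (0.09 log units; within the scatter). For compound 4 the value in this assay is estimated at 100 nM, within a range from 40 nM to 250 nM.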

Compound 4, half-maximal effective concentration: 85 nM
Beside the measured number, compound 4's estimate is 1.2-fold (0.07 log units) above it, within the range that was stated.
By their numbers in this assay, from the lowest: compound 1; then compounds 4, 3 and 2 (each within the scatter of the next).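

In this assay phenyl in place of cyclopentyl(methyl)amino on a sulfonyl sulfur gives a 1.4-fold lower number from compound 3 to compound 4 (0.16 log units; within the scatter) and hydrogen in place of chloro on an aromatic carbon gives a 1.5-fold lower number from compound 2 to compound 4 (0.17 log units; within the scatter) so phenyl, 4-chlorophenyl and cyclopentyl(methyl)amino on the sulfonyl sulfur cannot be told apart in this set. Within the data shown here, the one step beyond the scatter lies at the other end of the urea: pyridin-4-yl in place of 1H-pyrazol-4-yl on a saturated chain carbon bound to an amide-type nitrogen gives a 3.0-fold higher number from compound 1 to compound 4 (0.48 log units; beyond the scatter) with phenyl on the sulfonyl sulfur held constant. No available data explain these steps.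

On these data alone, whether a much smaller sulfonyl substituent such as methyl would stay within the scatter remains open. Also open, as far as these compounds go, is whether the 1H-pyrazol-4-yl step recurs with 4-chlorophenyl or cyclopentyl(methyl)amino on the sulfonyl sulfur.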